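Changing the group on sulfur in compound 1

The compounds below may be only part of what the source reports. "The series", "measured", "known", "first", "only" and "open" are said of these compounds alone.

Compound 1 `Cc1cc(C)cc(SCc2ccc(/C=C/C(=O)Nc3ccccc3N)cc2)c1`: 11.7%
Compound 2 `COc1ccc(SCc2ccc(C(=O)Nc3ccccc3N)cc2)cc1`: 35%
Compound 3 `Nc1ccccc1NC(=O)c1ccc(CSc2cccc(F)c2)cc1`: 22.5%

In a functional assay on HeLa cells (Homo sapiens) for inhibition, read by CCK-8 assay, with a stated time of 72 h, tested at 2 uM (a higher number here means more inhibition of growth at the concentration tested, a lower number less inhibition of growth), compound 1 stands lowest of the three, with 11.7%. Compound 4 `Nc1ccccc1NC(=O)/C=C/c1ccc(CSc2ccc(C(F)(F)F)cn2)cc1` keeps the core of compound 1 and differs only in the group on the sulfur: 5-(trifluoromethyl)pyridin-2-yl in place of 3,5-dimethylphenyl on a sulfur. Among the compounds with values here, the one measured step at that place is a number 12.5 percentage points lower from compound 2 to compound 3 (beyond the scatter), which is modest, involves a different pair of groups and sits on a different core, so it suggests a size more than a direction. Within the data shown here, with compound 1 at the bottom at 11.7%, a modest rise is expected, although no measured compound carries 5-(trifluoromethyl)pyridin-2-yl. The estimated change is a number 8.3 percentage points higher from compound 1 to compound 4 (within the scatter). For compound 4 the expected value is 20%, with an estimated range from 6% to 40%.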

Compound 4, percent growth inhibition at one concentration: 6.07%
The estimate for compound 4 lay 13.9 percentage points above the measured number; the measured number falls inside the stated range.
By their numbers in this assay, from the lowest: compounds 4 and 1 (each within the scatter of the next); then compound 3; then compound 2.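

Within the data shown here, this is the first step at the sulfur measured on the core of compound 1, and in this assay it reads a number 5.6 percentage points lower from compound 1 to compound 4 (within the scatter). On this core, then, 5-(trifluoromethyl)pyridin-2-yl and 3,5-dimethylphenyl cannot be told apart, even though the entering ring carries a hetero atom and the group has more heavy atoms. Among these compounds, the step seen on the other core has no counterpart here.

Going by these compounds, whether a group without an aromatic ring on the sulfur, such as cyclohexyl or a chain ending in an amine, would separate from these two remains open. No available data explain the result.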